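The source may report more compounds than this note shows. Statements on the series, on what has been measured and on what is new or still open speak of the compounds shown alone.

Measured in a functional assay on BCG823 cells (Homo sapiens) for cytotoxicity, read by MTT assay; on this read-out higher numbers stand for weaker inhibition and lower numbers for stronger inhibition:
- compound 1 `O=C(/C=C/c1cc(O)c(O)c([N+](=O)[O-])c1)OCCc1ccccc1`: 22900 nM
- compound 2 `COc1cc(/C=C/C(=O)OCCc2ccccc2)cc([N+](=O)[O-])c1O`: > 300000 nM (a limit)
- compound 3 `O=C(/C=C/c1ccc(O)c(O)c1[N+](=O)[O-])OCCc1ccccc1`: 27800 nM

Compound 2 reads > 300000 nM, a limit of this assay and not a number. Compound 2 stands at the limit of > 300000 nM in this assay, at which 1 of the 3 values shown sits.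

Compound 4 `COc1cc(/C=C/C(=O)OCCc2ccccc2)cc(Br)c1O` differs from compound 2 by one exchange: bromo in place of nitro on an aromatic carbon. This is bromo in place of nitro on an aromatic carbon, ortho to a hydroxy group.

Among the compounds with values here, no measured step covers this exchange. The nearest is an at least 13-fold higher number from compound 1 to compound 2 (1.11 log units; beyond the scatter), large, and compound 4 keeps that methyl, so a high number remains likely.

A modest step is expected: an at least 2.5-fold lower number from compound 2 to compound 4 (0.39 log units; beyond the scatter), toward a lower number, with a reading at the limit still possible. For compound 4 the estimated value is 120000 nM, with an expected range of 30000 nM to 300000 nM.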

Compound 4, half-maximal inhibitory concentration: > 300000 nM
Compound 4: a limit, no number (the forecaster's own chance of this, stated with the estimate: 45%); middle value at least 2.5-fold (0.39 log units) away from the limit.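

No step can be read from compound 2 to compound 4 in this assay, because both readings are limits and not numbers: the limit of > 300000 nM in this assay, at which 2 of the 4 values shown sit.

The compounds shown leave open whether bromo in place of nitro on an aromatic carbon changes the read-out at all.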